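Tert-butyl step from compound 2 to compound 4

This account rests on a few compounds, and the source may have more. Where it says the series, first, only, none or still open, it means among the compounds named here.

Series read in a functional assay on CEM-SS cells (Homo sapiens) for cytotoxicity; on this read-out lower numbers stand for stronger inhibition and higher numbers for weaker inhibition. Compound 2 (`Clc1cc2nc(Br)n(Cc3ccccc3)c2cc1Cl`) gives > 100000 nM, which is a limit of the assay and not a number. Its standing therefore has no measured value, only this limit. Compound 3 (`Clc1cccc(Cn2c(Br)nc3cc(Cl)c(Cl)cc32)c1`) gives > 100000 nM, again a limit. Compound 1 (`CC(C)(C)c1ccc(Cn2c(Cl)nc3cc(Cl)c(Cl)cc32)cc1`) also carries a tert-butyl and gives > 100000 nM, likewise a limit. The whole measured set comes down to the limit of > 100000 nM in this assay, at which 3 of the 3 values shown sit.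

Compound 4 (`CC(C)(C)c1ccc(Cn2c(Br)nc3cc(Cl)c(Cl)cc32)cc1`) follows from compound 2 by tert-butyl in place of hydrogen on an aromatic carbon, para to a large group: tert-butyl in place of hydrogen on an aromatic carbon.

Among the measured compounds shown here, the only measured change in one place is a step that the two limits leave unreadable from compound 2 to compound 3. It is a different substitution and has no readable size, so it offers no magnitude to carry over. For the measured compounds named here, the closer guide is compound 1, the one measured tert-butyl member, which shows no number in this assay either. No step beyond the scatter is therefore expected, and no direction can be assigned.

The expected change is a number no higher from compound 2 to compound 4 (the limit leaves the size open), most likely seen as no readable step at all. For compound 4 the estimated value is 100000 nM, with an expected range from 50000 nM to 200000 nM.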

Compound 4, half-maximal inhibitory concentration: > 100000 nM
Compound 4: no number, only a limit; the forecaster's own chance of this, stated with the estimate: 90%; the middle value sits exactly at the limit.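

In this assay compound 4 gives > 100000 nM, a limit and not a number. No new step can be read, neither from compound 2 to compound 4 nor from compound 1 to compound 4. The compounds shown leave open whether any change on the shared core moves the read-out, because the set offers only this: the limit of > 100000 nM in this assay, at which 4 of the 4 values shown sit.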